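The source may hold more compounds than are shown below. What is called first, only, known or untested is meant among the compounds shown, and "the series" means these compounds.

Measured in a functional assay on BT-549 cells (Homo sapiens) for inhibition, read by sulforhodamine B assay, with a stated time of 48 h, tested at 0.1 uM; a lower number here means a stronger effect, a higher number a weaker effect of the compound at the concentration tested:
compound 1, `O=C(Nc1cccc(-n2cc(-c3ccncc3)c(-c3cc(O)cc(Cl)c3)n2)c1)Nc1ccc(Cl)c(C(F)(F)F)c1`: 95%
compound 2, `O=C(Nc1cccc(-n2cc(-c3ccncc3)c(-c3cc(O)cc(Cl)c3)n2)c1)Nc1ccc(Cl)c(Cl)c1`: 93%
compound 3, `COc1cc(Cl)cc(-c2nn(-c3cccc(NC(=O)Nc4cc(C(F)(F)F)cc(C(F)(F)F)c4)c3)cc2-c2ccncc2)c1`: 89%

Compound 3 carries the smallest of the three numbers, yet its gap to compound 2 and its wider gap to compound 1 both lie within the scatter, so the three compounds stand level in this assay.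

Compound 4, `COc1cc(Cl)cc(-c2nn(-c3cccc(NC(=O)Nc4cccc(C(F)(F)F)c4)c3)cc2-c2ccncc2)c1`, differs from compound 3 in one place: hydrogen in place of trifluoromethyl on an aromatic carbon. For the measured compounds named here, only one measured step touches the same region, the replacement of a group on the urea-bound ring in a number 2 percentage points lower from compound 1 to compound 2 (within the scatter), a step that stayed within the scatter. That step swaps one group for another rather than removing one, so it bears on the present change only loosely. With nothing beyond the scatter among the measured compounds, no step beyond the scatter is expected from compound 3 to compound 4 in this assay, that is a number 1 percentage points higher from compound 3 to compound 4 (within the scatter). Compound 4 is therefore estimated at 90%, within 78% to 98%.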

Compound 4, a percentage reported as activity, at one concentration (the size of the read-out at that concentration, not a potency): 114%
For compound 4 the middle estimate is 24 percentage points below the measured one, and the stated range ends below it.
By their numbers in this assay, from the lowest: compounds 3, 2 and 1 (each within the scatter of the next); then compound 4.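

In this assay, replacing trifluoromethyl with hydrogen on this aromatic carbon, which is meta to a large group and meta to a trifluoromethyl group that stays in place, gives a number 25 percentage points higher from compound 3 to compound 4 (beyond the scatter) and so a weaker effect at the concentration tested. For the compounds shown here, this is the first step to lie beyond the scatter, whereas the one earlier step, a number 2 percentage points lower from compound 1 to compound 2 (within the scatter), exchanged one group for another in a different pair and did not reach that size. The compounds shown thus reveal that this position responds to the loss of its trifluoromethyl group, but no measurement at hand explains the step.

On these data alone, it remains open whether a methyl group, a nitrile or an amine at this carbon would keep the number of compound 3 or move it as hydrogen does. As far as these compounds go, it is also open whether the same replacement would have a similar effect in a compound carrying the hydroxyl group of compound 1 and compound 2.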